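A few compounds are considered here, and "the series" means these few. Any claim that something is new, unique, unknown or untested is made for them only; others in the source may bear on it.

Measured compounds:
Compound 1, `CCCCc1nc2c(-c3ccc(Cl)cc3)n[nH]c2c(=O)n1NC(=O)c1ccccc1`: 29100 nM
Compound 2, `O=C(Nn1c(CCC2CCCC2)nc2c(-c3ccc(Cl)cc3)n[nH]c2c1=O)c1ccccc1`: 10200 nM

Both values come from a functional assay on DU-145 cells (Homo sapiens) for inhibition, read by MTT assay, with a stated time of 2 days; a lower number here means a stronger inhibitor of growth, a higher number a weaker inhibitor of growth. Compound 2 stands at the lower of the two numbers, and its nearest neighbour is compound 1, separated by a 2.9-fold lower number from compound 1 to compound 2 (0.46 log units; beyond the scatter). For the measured compounds named here, that one step is the only measured step in the set, and it concerns the saturated chain on the shared core.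

Compound 3, `CC(C)(C)c1ccc(C(=O)Nn2c(CCC3CCCC3)nc3c(-c4ccc(Cl)cc4)n[nH]c3c2=O)cc1`, is the compound not yet measured. It differs from compound 2 by tert-butyl in place of hydrogen on an aromatic carbon. Going by the values given here, this change sits on the benzoyl part, a place where nothing has yet been varied, so the single measured step from compound 1 to compound 2 does not bear on it: the chain and the benzoyl part are separate ends of the molecule. Among the compounds with values here, with no step touching the benzoyl part, the expectation for compound 3 rests on compound 2 alone. The step is therefore expected to be about a 1.3-fold lower number from compound 2 to compound 3 (0.11 log units; within the scatter) in this assay, that is, none beyond the scatter, with the range widened to allow for either direction. Compound 3 is accordingly estimated at 8000 nM, within 2500 nM to 25000 nM.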

Compound 3, concentration for 50% growth inhibition: 21500 nM
Beside the measured number, compound 3's estimate is 2.7-fold (0.43 log units) below it; low and high end bracket the measured number.
By their numbers in this assay, from the lowest: compound 2; then compounds 3 and 1 (each within the scatter of the next).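

In this assay, the benzoyl end of the molecule turns out to respond to substitution: placing tert-butyl on the aromatic carbon, so that phenyl becomes 4-(tert-butyl)phenyl, gives a 2.1-fold higher number from compound 2 to compound 3 (0.32 log units; beyond the scatter). For the compounds shown here, this is the first measured change at that end, and it moves toward weaker growth inhibition, the opposite direction to the one earlier step on the saturated chain, a 2.9-fold lower number from compound 1 to compound 2 (0.46 log units; beyond the scatter). The step is modest, however, and nothing available here accounts for it.

With tert-butyl the only group shown on this ring, it remains open whether the shift is particular to that group or would also appear with a smaller one, such as methyl or chlorine, or with a different kind of group, such as an amine or a carboxylic acid. As far as these compounds go, it is also open whether the tert-butyl change would give a similar step on the chain of compound 1, which would show whether the two ends of the molecule act independently of each other.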